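The compounds below may be only part of what the source reports. "The series", "measured", "known", "first", "only" and "open" are said of these compounds alone.

In an ADME assay on CEM-SS cells (Homo sapiens) for cytotoxicity, read by XTT assay (on this read-out higher numbers stand for lower toxicity in this test and lower numbers for higher toxicity in this test), compound 1 `CN(O)C(=O)c1cc2ccn(Cc3ccc(F)cc3)c2cn1` gives 135000 nM. Compound 2 `CN(O)C(=O)c1cc2c(CN3CCC(O)C3)cn(Cc3ccc(F)cc3)c2cn1` gives > 100000 nM, which is a limit of the assay and not a number. Among the compounds with values here, compound 3 `CCOCCOCc1cn(Cc2ccc(F)cc2)c2cnc(C(=O)N(C)O)cc12` gives 81000 nM, which lies within the scatter of the value of compound 1, the only other true number in the set. Compound 4 `COCCOCCCc1cn(Cc2ccc(F)cc2)c2cnc(C(=O)N(C)O)cc12` differs from compound 3 by 2-(2-methoxyethoxy)ethyl in place of 2-ethoxyethoxy on a saturated chain carbon bound to an aromatic carbon, with 2-(2-methoxyethoxy)ethyl in place of 2-ethoxyethoxy on a saturated chain carbon bound to an aromatic carbon.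

Within the data shown here, the closest precedent is the addition of the (2-ethoxyethoxy)methyl group, a 1.7-fold lower number from compound 1 to compound 3 (0.22 log units; within the scatter). The exchange of side chains gives an at least 1.2-fold lower number from compound 2 to compound 3 (0.09 log units; that floor lies within the scatter), while the remaining measured step, a step that the limit leaves unreadable from compound 1 to compound 2, offers no size. Neither readable step leaves the scatter, so no shift beyond it is expected in this assay. The expected change is a 1.0-fold lower number from compound 3 to compound 4 (0.01 log units; within the scatter). Compound 4 is estimated at 80000 nM, with an expected range of 40000 nM to 150000 nM.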

Compound 4, half-maximal cytotoxic concentration: > 10000 nM
Compound 4 ended at the assay's limit; the forecaster's own chance of this, stated with the estimate: 20%; the middle value is on the limit's open side.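

In this assay compound 4 gives > 10000 nM, which is a limit of the assay and not a number. Within the data shown here, no step from compound 1, compound 2 or compound 3 to compound 4 can be read. The compounds shown leave open whether the 3-(2-methoxyethoxy)propyl chain of compound 4 changes the read-out at all.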